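Swapping chloro for an amine chain: expected half-life

A few compounds are considered here, and "the series" means these few. Any claim that something is new, unique, unknown or untested is made for them only; others in the source may bear on it.

Among the compounds with values here, in an ADME assay for pharmacokinetics, read by LC-MS, in phosphate buffer, with a stated time of 120 min, at pH 7.4, tested at 1 uM, in the presence of a further agent that is not named here (a higher number here means that the compound lasts longer, a lower number that the compound disappears faster), compound 1 `C=C(Cl)C(=O)Nc1ccccc1` gives 0.05 h as the lowest number so far, while compound 3 `O=C(/C=C/CN1CCCC1)Nc1ccccc1` gives 2.7 h as the only other exact number. Compound 2 `C/C=C/C(=O)Nc1ccccc1` gives > 8.53 h as a limit of the assay and not a number.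

Compound 4 `C=C(CN(C)C)C(=O)Nc1ccccc1` is unmeasured. Its change from compound 1 is (dimethylamino)methyl in place of chloro on a double-bonded chain carbon bound to a carbonyl carbon with (dimethylamino)methyl in place of chloro on a double-bonded chain carbon bound to a carbonyl carbon. Within the data shown here, no measured step makes this exact swap, but two bear on it. The large step of an at least 170-fold higher number from compound 1 to compound 2 (2.23 log units; beyond the scatter) puts prop-1-en-1-yl in place of 1-chloroethenyl. The at least modest step an at least 3.1-fold lower number from compound 2 to compound 3 (0.49 log units; beyond the scatter) adds pyrrolidin-1-yl and goes back down.

Compound 3 at 2.7 h is the closest measured match to compound 4, which also loses the chloro and carries an amine group. A large rise is therefore expected, namely a 30-fold higher number from compound 1 to compound 4 (1.48 log units; beyond the scatter) in this assay and beyond the scatter. Compound 4 is estimated at 1.5 h with an expected range from 0.4 h to 6 h in this assay's half-life.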

Compound 4, half-life: < 0.0334 h
Compound 4 ended at the assay's limit; the forecaster's own chance of this, stated with the estimate: 10%; at least 44-fold (1.65 log units) between middle value and limit.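

In this assay, compound 4 gives < 0.0334 h, which is a limit of the assay and not a number. On a double-bonded chain carbon bound to a carbonyl carbon, putting (dimethylamino)methyl in place of chloro gives an at least 1.4-fold lower number from compound 1 to compound 4 (0.17 log units; that floor lies within the scatter), so this swap brings no measurable gain in half-life. The earlier steps shown here replaced the whole 1-chloroethenyl group, whereas this one replaces only the chloro, and it shows that losing the chloro at this place is not enough on its own to make the compound last longer.

From the compounds shown here alone, the exact half-life of compound 4 remains open, and with it whether compound 4 truly disappears faster than compound 1. Also open, going by these compounds, is whether a carboxylic acid or a longer amine chain on this same carbon would last longer.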